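Cytotoxicity notes on three measured compounds and one pending

The compounds below may be only part of what the source reports. "The series", "measured", "known", "first", "only" and "open" are said of these compounds alone.

Measured so far:
compound 1, `CN1CCN(c2cccc3nc(CN(C)[C@H]4CCCc5cccnc54)[nH]c23)CC1`: > 5000 nM
compound 2, `CN1CCN(c2cccc3nc(CN(C)[C@@H]4CCCc5cccnc54)cn23)CC1`: 12600 nM
compound 3, `CN1CCC(N(C)c2cccc3nc(CN(C)[C@H]4CCCc5cccnc54)cn23)C1`: 10800 nM

In an ADME assay on HOS cells (Homo sapiens) for cytotoxicity (a higher number here means that more compound is tolerated, a lower number that less compound is tolerated), compound 1 gives a limit of the assay rather than a number, > 5000 nM; this is the limit of > 5000 nM in this assay, at which 1 of the 3 values shown sits. Compound 2 gives 12600 nM in this assay. Compound 3 gives 10800 nM in this assay, the lower of the two numbers, with the gap to compound 2 lying within the usual scatter, so no order between these two can be read.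

Compound 4, `CN(Cc1cn2c(N3CCN4CCCC4C3)cccc2n1)[C@H]1CCCc2cccnc21`, remains to be measured in this assay. Relative to compound 3 the change is a group of 9 heavy atoms (7 carbon, 2 nitrogen; one five-membered non-aromatic ring with 1 hetero atom, one six-membered non-aromatic ring with 2 hetero atoms) in place of a group of 8 heavy atoms (6 carbon, 2 nitrogen; one five-membered non-aromatic ring with 1 hetero atom), on an aromatic carbon. Within the data shown here, no measured pair differs at this position, so no step can be drawn on; the two measured numbers sit close together and the third value is only a limit. The expectation for this assay is therefore a step of no size beyond the scatter, in neither direction. Compound 4 is estimated at 10000 nM, with a range from 4000 nM to 25000 nM. The expected step is a 1.1-fold lower number from compound 3 to compound 4 (0.03 log units; within the scatter).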

Compound 4, half-maximal cytotoxic concentration: 3900 nM
Beside the measured number, compound 4's estimate is 2.6-fold (0.41 log units) above it; the whole stated range lies above it.
By their numbers in this assay, from the lowest: compound 4; then compounds 3 and 2 (each within the scatter of the next).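

In this assay, among these compounds, the aromatic carbon next to the ring nitrogen proves sensitive to the amine placed on it: a 2.8-fold lower number from compound 3 to compound 4 (0.44 log units; beyond the scatter) is the only step at this position, and it lies beyond the scatter. Methyl(1-methylpyrrolidin-3-yl)amino and the entering group, which has one five-membered and one six-membered non-aromatic ring, have the same counts of hydrogen-bond donors and acceptors and no net charge, so these counts do not separate the pair. No measurement shown accounts for the step.

From the compounds shown here alone, the finding rests on this one pair, so it remains open whether the lower number follows from the added six-membered ring or from the particular fused arrangement. Going by these compounds, a morpholine or a primary amine on this carbon would test how far the trend extends, and its direction for such groups is unknown.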